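This account rests on a few compounds, and the source may have more. Where it says the series, first, only, none or still open, it means among the compounds named here.

Measured so far:
- compound 1, `O=C(NCc1ccc(S(=O)(=O)c2ccccc2)cc1)c1cc2ccncc2s1`: 14 nM
- compound 2, `O=C(NCc1ccc(S(=O)(=O)N2CCCCC2)cc1)c1cc2cccnc2s1`: > 10000 nM

Compound 1 carries the only actual number shown in a functional assay on A2780 cells (Homo sapiens) for inhibition, read by sulforhodamine B assay, with a stated time of 72 h (a lower number here means a stronger inhibitor, a higher number a weaker inhibitor), giving 14 nM. For compound 2 this assay reports only a limit, > 10000 nM, so it is not a number and stands as the limit of > 10000 nM in this assay, at which 1 of the 2 values shown sits. No step between two measured compounds is shown here, so there is nothing measured to say how one change in structure moves potency.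

Compound 3, `O=C(NCc1ccc(S(=O)(=O)c2ccccc2)cc1)c1cc2cnccc2[nH]1`, has not yet been measured. It differs from compound 1 in one place: a group of 9 heavy atoms (7 carbon, 2 nitrogen; one five-membered aromatic ring with 1 hetero atom, one six-membered aromatic ring with 1 hetero atom) in place of a group of 9 heavy atoms (7 carbon, 1 nitrogen, 1 sulfur; one five-membered aromatic ring with 1 hetero atom, one six-membered aromatic ring with 1 hetero atom), on a carbonyl carbon. In this assay a small loss of potency is expected, perhaps within the usual scatter, perhaps slightly beyond it. Compound 3 is estimated at 50 nM, between 10 nM and 500 nM, which means an expected step of a 3.6-fold higher number from compound 1 to compound 3 (0.55 log units; beyond the scatter).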

Compound 3, half-maximal inhibitory concentration: 18 nM
Compound 3: middle estimate off by 2.8-fold (0.44 log units), on the high side; the measured number falls inside the stated range.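

Among these compounds, the change on the carbonyl carbon gives a 1.3-fold higher number from compound 1 to compound 3 (0.11 log units; within the scatter) in this assay and is the first measured step in this set. It shows that this position takes the group with 1 hydrogen-bond donor and no sulfur in place of the sulfur-containing group with no step beyond the scatter, so the two groups cannot be told apart in this test. Nothing measured here explains why the two groups read alike.

Still open, going by these compounds, is whether a smaller group on the same carbonyl carbon would read the same, such as a single six-membered aromatic ring with 1 hetero atom and no five-membered ring. Also open, on these data alone, is how a methyl group in place of the hydrogen on the donor of the entering group would read.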